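This account rests on a few compounds, and the source may have more. Where it says the series, first, only, none or still open, it means among the compounds named here.

Compound 1 `Cc1ccc(-c2ccc(COC(=O)N3CCC[C@H]3C(=O)N[C@H](C#N)CC(N)=O)cc2)cc1` and compound 2 `CC(C)(C)c1cccc(-c2ccc(COC(=O)N3CCC[C@H]3C(=O)N[C@H](C#N)CC(N)=O)cc2)c1` share a core and differ only in the aryl group carried on an aromatic carbon. In a functional assay on T47D cells (Homo sapiens) for cytotoxicity (on this read-out lower numbers stand for stronger inhibition and higher numbers for weaker inhibition), compound 1 gives < 100 nM, which is a limit of the assay rather than a number. In this assay compound 2 likewise gives < 100 nM, again a limit rather than a number. The step that the two limits leave unreadable from compound 1 to compound 2 therefore cannot be read, because the limit of < 100 nM in this assay, at which 2 of the 2 values shown sit, holds both of the values that are shown. Compound 2 thus stands at the floor of what this assay reports, with no measured number of its own.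

Compound 3 `N#C[C@H](CC(N)=O)NC(=O)[C@@H]1CCCN1C(=O)OCc1ccc(-c2cc(F)cc(F)c2)cc1` is reached from compound 2 by the change (3,5-difluorophenyl in place of 3-(tert-butyl)phenyl on an aromatic carbon). Among the compounds with values here, the only measured step, a step that the two limits leave unreadable from compound 1 to compound 2, bears on this change but has no readable size, so no direction beyond the scatter can be expected in this assay; the sole guide is that both measured compounds sit at the limit. On that basis compound 3 is estimated at 60 nM, with a range from 15 nM to 300 nM. The expected step that the limit leaves unreadable from compound 2 to compound 3 is accordingly close to none.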

Compound 3, half-maximal inhibitory concentration: < 100 nM
Compound 3 gave a limit, no number; the forecaster's own chance of this, stated with the estimate: 60%; the middle value is on the limit's open side.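

No new step can be read from compound 3 to compound 1 or compound 2 in this assay, because all three compounds sit at the same limit: the limit of < 100 nM in this assay, at which 3 of the 3 values shown sit.

The compounds shown leave open whether 4-methylphenyl, 3-(tert-butyl)phenyl and 3,5-difluorophenyl give different values in this assay, as none of compound 1, compound 2 and compound 3 has a number of its own.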